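Phenyl to 5-fluoropyridin-2-yl on the ether oxygen

The source may hold more compounds than are shown below. What is called first, only, known or untested is meant among the compounds shown, and "the series" means these compounds.

Measured so far:
compound 1 `O=C1c2cc(COc3ccccc3)nn2CCN1c1ccc(F)cc1`: 79%
compound 2 `O=C1c2cc(COc3ccccc3)nn2CCN1c1ccc(F)cn1`: 72%

In a functional assay on HEK293 cells for positive allosteric modulation of metabotropic glutamate receptor 5 (Homo sapiens), read by calcium flux (on this read-out higher numbers stand for larger maximal responses and lower numbers for smaller maximal responses), compound 1 gives 79%; compound 2 gives 72%, a number within the scatter of compound 1, so the two cannot be ranked. Compound 3 `O=C1c2cc(COc3ccc(F)cn3)nn2CCN1c1ccc(F)cc1` differs from compound 1 by 5-fluoropyridin-2-yl in place of phenyl on an oxygen on a saturated carbon. Among the compounds with values here, the only measured step, a number 7 percentage points lower from compound 1 to compound 2 (within the scatter), made the same exchange at the amide-type nitrogen in a ring rather than at the oxygen on a saturated carbon, and stayed within the scatter. Within the data shown here, no step at the oxygen itself has been measured. The step of a number 4 percentage points lower from compound 1 to compound 3 (within the scatter) is therefore expected to be small, with no direction beyond the scatter. Compound 3 is estimated at 75%, between 60% and 88%.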

Compound 3, largest response reached (Emax), in percent of the reference or control that the assay uses: 52%
For compound 3 the middle estimate is 23 percentage points above the measured one; measured number below the stated range.
By their numbers in this assay, from the lowest: compound 3; then compounds 2 and 1 (each within the scatter of the next).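

In this assay, within the data shown here, the exchange on the oxygen on a saturated carbon gives the first step beyond the scatter: a number 27 percentage points lower from compound 1 to compound 3 (beyond the scatter). This position therefore responds to 5-fluoropyridin-2-yl in place of phenyl, whereas the step at the amide-type nitrogen in a ring, a number 7 percentage points lower from compound 1 to compound 2 (within the scatter), does not separate its two compounds. Nothing available bears on the reason for the drop. As far as these compounds go, whether pyridin-2-yl or 4-fluorophenyl on that oxygen would keep the response of compound 1 remains open. So does whether the ring nitrogen or the fluorine accounts for the step.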